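Replacing a diethylamino group with a bicyclic amine

The compounds below may be only part of what the source reports. "The series", "measured", "known", "first", "only" and "open" are said of these compounds alone.

Compound 1 `CCN(CC)CCCOc1ccc2cc(NC(=O)c3ccc(O)c(CC=C(C)C)c3)c(=O)oc2c1C` carries a diethylamino group at the end of a short chain attached through an oxygen to the shared core. In a functional assay on SK-BR-3 cells (Homo sapiens) for antiproliferative activity (a higher number here means a weaker inhibitor, a lower number a stronger inhibitor), compound 1 gives 4900 nM, the highest of the three numbers measured, so it is the weakest inhibitor of the set. Compound 2 `CC(C)=CCc1cc(C(=O)Nc2cc3ccc(OCCCNCC(C)C)c(C)c3oc2=O)ccc1O` gives 1030 nM and compound 3 `CC(C)=CCc1cc(C(=O)Nc2cc3ccc(OCCCNCC(N)=O)c(C)c3oc2=O)ccc1O` gives 2290 nM in this assay.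

Compound 4 `CC(C)=CCc1cc(C(=O)Nc2cc3ccc(OCCCN[C@@H]4C[C@H]5CC[C@@H]4C5)c(C)c3oc2=O)ccc1O` has not yet been measured. It differs from compound 1 in one place: a group of 8 heavy atoms (7 carbon, 1 nitrogen; 2 five-membered non-aromatic rings of carbon only) in place of a group of 5 heavy atoms (4 carbon, 1 nitrogen; no ring), on a saturated chain carbon, three bonds along the chain from an oxygen on an aromatic ring. Among the compounds with values here, two measured steps bear on this change, since both also trade the diethylamino group for an amine bearing a single carbon substituent. The step of a 4.8-fold lower number from compound 1 to compound 2 (0.68 log units; beyond the scatter) and the step of a 2.1-fold lower number from compound 1 to compound 3 (0.33 log units; beyond the scatter) both lowered the number, the larger change coming with the hydrocarbon substituent. Compound 4 also carries a hydrocarbon substituent, here a larger one with two rings, so a lowering of similar size to the step to compound 2 is expected, roughly a 4.1-fold lower number from compound 1 to compound 4 (0.61 log units; beyond the scatter). Compound 4 is therefore estimated to give 1200 nM in this assay, with a range from 500 nM to 3000 nM.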

Compound 4, half-maximal inhibitory concentration: 770 nM
Compound 4: middle estimate off by 1.6-fold (0.19 log units), on the high side; measured number inside the range.
By their numbers in this assay, from the lowest: compounds 4 and 2 (each within the scatter of the next); then compound 3; then compound 1.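

In this assay, a much larger amine substituent, with two five-membered rings of carbon only, is accepted at the end of this chain (a 6.4-fold lower number from compound 1 to compound 4 (0.80 log units; beyond the scatter)). Among the compounds with a secondary amine here, both all-carbon substituents give lower numbers than the carbamoylmethyl group of compound 3, and the ring-bearing group continues that pattern (a 3.0-fold lower number from compound 3 to compound 4 (0.47 log units; beyond the scatter)). Exchanging the isobutyl group for the ring-bearing group makes no difference beyond the scatter (a 1.3-fold lower number from compound 2 to compound 4 (0.13 log units; within the scatter)), so the added rings and heavy atoms bring no clear change over compound 2.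

Still open, on these data alone, is how a cyclohexylamino group, a longer chain or the mirror-image form of the ring-bearing group would compare. No measurement shown here explains any of these steps.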